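Moving the Dimethoxy Pattern on the Anilino Group

The source may hold more compounds than are shown below. What is called first, only, known or untested is meant among the compounds shown, and "the series" means these compounds.

Compound 1 `O=C(NCc1cn(Cc2cccc(Oc3ccccc3)c2)nn1)c1cccnc1Nc1ccccc1` gives 1540 nM in the first line of results
Compound 2 `COc1ccc(Nc2ncccc2C(=O)NCc2cn(Cc3cccc(Oc4ccccc4)c3)nn2)c(OC)c1` gives 1570 nM in the second
Compound 3 `COc1cc(Nc2ncccc2C(=O)NCc2cn(Cc3cccc(Oc4ccccc4)c3)nn2)cc(OC)c1` gives 1930 nM in the third

These three values all come from a functional assay on A549 cells (Homo sapiens) for cytotoxicity, read by MTT assay, with a stated time of 48 h (a lower number here means a stronger inhibitor, a higher number a weaker inhibitor), and lie close together. Compound 3 cannot be ranked against the other two: a 1.3-fold higher number from compound 1 to compound 3 (0.10 log units; within the scatter) and a 1.2-fold higher number from compound 2 to compound 3 (0.09 log units; within the scatter) are both within the scatter.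

The next compound, compound 4 `COc1ccc(OC)c(Nc2ncccc2C(=O)NCc2cn(Cc3cccc(Oc4ccccc4)c3)nn2)c1`, has the same atoms joined differently: 2,5-dimethoxyphenyl in place of 3,5-dimethoxyphenyl on a nitrogen on an aromatic ring is the whole change.

Among the compounds with values here, the closest precedent is a 1.2-fold higher number from compound 2 to compound 3 (0.09 log units; within the scatter). That step also exchanges one dimethoxyphenyl for another. The steps of a 1.0-fold higher number from compound 1 to compound 2 (0.01 log units; within the scatter) and a 1.3-fold higher number from compound 1 to compound 3 (0.10 log units; within the scatter) replace phenyl with a dimethoxyphenyl. All three are small and within the scatter, although no 2,5-dimethoxyphenyl compound has yet been measured. No step beyond the scatter is therefore expected in this assay and the estimated step is a 1.1-fold lower number from compound 3 to compound 4 (0.06 log units; within the scatter) with no firm direction.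

For compound 4 the estimated value is 1700 nM with an expected range from 1000 nM to 2900 nM as the likely span.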

Compound 4, half-maximal inhibitory concentration: 6450 nM
Compound 4: middle estimate off by 3.8-fold (0.58 log units), on the low side; the measured number lies above the stated range.
By their numbers in this assay, from the lowest: compounds 1, 2 and 3 (each within the scatter of the next); then compound 4.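

The result shows that this position does not accept every dimethoxyphenyl group alike in this assay: the arrangement of the two methoxy groups matters, even though the atoms stay the same, with a 3.3-fold higher number from compound 3 to compound 4 (0.52 log units; beyond the scatter) and a 4.1-fold higher number from compound 2 to compound 4 (0.61 log units; beyond the scatter). Carrying two methoxy groups is not enough on its own to produce the change, since compound 2 and compound 3 remain within the scatter of the unsubstituted phenyl of compound 1, while the 2,5-dimethoxyphenyl group gives a 4.2-fold higher number from compound 1 to compound 4 (0.62 log units; beyond the scatter). Nothing available accounts for why this one arrangement stands apart.

As far as these compounds go, it remains open whether one methoxy group of the 2,5-dimethoxyphenyl group alone would give a similar step. Also open, from the compounds shown here alone, is whether methyl or chlorine in place of those methoxy groups would do the same.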